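The source may hold more compounds than are shown below. What is called first, only, known or untested is meant among the compounds shown, and "the series" means these compounds.

Measured so far:
compound 1 `CCCc1cc(N)c2cc(NC(=O)CCc3ccccc3)ccc2n1`: 8300 nM
compound 2 `CCCc1cc(N2CCCC2)c2cc(NC(=O)/C=C/c3ccc(C(F)(F)F)cc3)ccc2n1`: 17 nM
compound 3 `CCCc1cc(N)c2cc(NC(=O)/C=C/c3ccc(C(C)C)cc3)ccc2n1`: 2.9 nM

In an assay on isolated protein for displacement of a labelled ligand from melanin-concentrating hormone receptor 1 (Homo sapiens) (on this read-out lower numbers stand for stronger inhibition and higher numbers for weaker inhibition), compound 3 gives 2.9 nM, the lowest of the three numbers; compound 2 comes nearest, and compound 1 lies furthest away, both gaps beyond the scatter, so compound 3 is the most potent compound measured here. Compound 4 `CCCc1cc(N)c2cc(NC(=O)/C=C/c3ccc(Cl)cc3)ccc2n1` differs from compound 3 in one place: chloro in place of isopropyl on an aromatic carbon. Within the data shown here, no pair of measured compounds isolates this exchange, so nothing in the data sets its size. The change is expected to cost a little potency, with a step of a 2.8-fold higher number from compound 3 to compound 4 (0.44 log units; beyond the scatter) from compound 3 to compound 4 that stays small. Compound 4 is therefore estimated at 8 nM in this assay, within a range from 2 nM to 30 nM.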

Compound 4, half-maximal inhibitory concentration: 6 nM
Beside the measured number, compound 4's estimate is 1.3-fold (0.12 log units) above it; the measured number falls inside the stated range.
By their numbers in this assay, from the lowest: compound 3; then compound 4; then compound 2; then compound 1.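

In this assay, among these compounds, the exchange of 4-isopropylphenyl for 4-chlorophenyl gives the first measured step at this position, a 2.1-fold higher number from compound 3 to compound 4 (0.32 log units; beyond the scatter) and this step is modest, though beyond the scatter. One chlorine atom in place of the three carbons of isopropyl therefore costs only a little potency, and both compounds keep low numbers. Nothing available here explains the size of this step. The compounds shown leave open how a methoxy group, a nitrile or a carboxylic acid would fare at this position. They also leave open whether this exchange gives a similar step with a different group elsewhere on the shared core.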